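A few compounds are considered here, and "the series" means these few. Any claim that something is new, unique, unknown or untested is made for them only; others in the source may bear on it.

Working notes on the series.

The series is read in an ADME assay on CCD-1095SK cells (Homo sapiens) for antiproliferative activity, read by crystal violet staining, with a stated time of 96 h; on this read-out higher numbers stand for an effect only at larger amounts of compound and lower numbers for an effect already at smaller amounts. Compound 1 `O[C@@H]1CO[C@@H](Oc2ccc3ccccc3c2)C[C@H]1O` gives 19 uM in this assay. Compound 2 `CO[C@H]1[C@H](Oc2ccc3ccccc3c2)OC[C@@H](O)[C@@H]1O` carries one change against compound 1, (methoxy in place of hydrogen on a saturated ring carbon), and in this assay compound 2 gives 55 uM; the step is a 2.9-fold higher number from compound 1 to compound 2 (0.46 log units; beyond the scatter). Compound 3 `O[C@H]1[C@H](Oc2ccc3ccccc3c2)OCC[C@@H]1O` is built on a core that differs from the core of compound 1; the difference between the two cores is not broken down here. In this assay compound 3 gives 285 uM, the highest number of the three measured compounds, beyond the scatter from compound 2 and from compound 1.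

Compound 4 `CO[C@@H]1CO[C@@H](Oc2ccc3ccccc3c2)[C@H](O)[C@H]1O` is not yet measured. Against compound 3 it carries methoxy in place of hydrogen on a saturated ring carbon. Among the compounds with values here, this is the same kind of change as the one from compound 1 to compound 2, but not the same: in compound 2 the methoxy sits next to the ring atom that bears the large group, while in compound 4 it sits three ring bonds from the ring atom that bears the large group, and in both cases it is next to the ring atom that bears a hydroxy group and two ring bonds from the ring oxygen. The step from compound 1 to compound 2 gave a modest rise in the number, and on that single precedent a step of similar direction and size is expected from compound 3 to compound 4, with wide uncertainty since the core and the placement differ, and the estimate is a 2.5-fold higher number from compound 3 to compound 4 (0.39 log units; beyond the scatter). Starting from compound 3, compound 4 is expected to give about 700 uM in this assay, with a range from 250 uM to 2000 uM.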

Compound 4, concentration for half-maximal effect: 93 uM
Compound 4: the middle estimate sits 7.5-fold (0.88 log units) above what was measured; the measured number lies below the stated range.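

In this assay the new step is a 3.1-fold lower number from compound 3 to compound 4 (0.49 log units; beyond the scatter). Set beside the earlier step, the direction reverses, so in this series the result of putting methoxy in place of hydrogen on a saturated ring carbon on one core does not predict its result on the other: the same change on two cores in this assay, a 2.9-fold higher number (0.46 log units; beyond the scatter) from compound 1 to compound 2 and a 3.1-fold lower number (0.49 log units; beyond the scatter) from compound 3 to compound 4, 8.9-fold (0.95 log units) apart, beyond the scatter of two such steps

This rests on one pair for each core, and the methoxy does not sit at the same ring place in compound 2 and compound 4, where it stands three ring bonds from the ring atom that bears a large group; the two steps therefore do not separate the core from the placement, and they give no rule for any other core.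

The compounds shown leave open whether methoxy at one and the same ring place would move the number in the same direction on both cores. They also leave open whether a longer chain such as ethoxy, or an amine, at that ring place would follow methoxy on each core or depart from it.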